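The compounds below may be only part of what the source reports. "The series", "measured", "known", "first", "only" and "open" are said of these compounds alone.

In a functional assay on the whole organism (strain CD-1) with Mus musculus as the target, with a stated time of 2 h (a lower number here means that less compound is needed, a higher number that more compound is needed for the effect), the shared core carries an aryl group on the amine nitrogen of the piperazine-like ring, and the identity of that aryl group decides the outcome. Compound 1 `CC1(c2ccccc2)CC(=O)N(CC(=O)N2CCN(c3ccccc3F)CC2)C1=O` gives 300 mg/kg, while compound 2 `CC1(c2ccccc2)CC(=O)N(CC(=O)N2CCN(c3ccccc3Cl)CC2)C1=O` gives 100 mg/kg; the step of a 3.0-fold lower number from compound 1 to compound 2 (0.48 log units; beyond the scatter) brings chloro in place of fluoro on an aromatic carbon. Compound 3 `CC1(c2ccccc2)CC(=O)N(CC(=O)N2CCN(c3cccc(Cl)c3Cl)CC2)C1=O` is recorded as "not active" (no number reported), so no number places it on the scale next to compound 1 and compound 2. Compound 4 `CC1(c2ccccc2)CC(=O)N(CC(=O)N2CCN(c3ccc(Cl)c(Cl)c3)CC2)C1=O` differs from compound 3 only in the arrangement of the same atoms: 3,4-dichlorophenyl in place of 2,3-dichlorophenyl on an amine nitrogen in a ring. No measured step rearranges two chloro substituents on that aryl ring, so the single step from compound 1 to compound 2 does not bear directly on this change, and the direction cannot be read from the numbers shown. Given that compound 2 with one chloro gives 100 mg/kg while compound 3 with two gives "not active" (no number reported), compound 4 is expected to fall near 300 mg/kg, in a range from 100 mg/kg to 1000 mg/kg, with a real chance that this assay again reports no number.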

Compound 4, minimum effective dose: "not active" (no number reported)
Compound 4: no number reported; the estimate stays without a comparison.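

Compound 3 and compound 4 both lack a number, so no step can be read between them, and no evidence shown bears on this result. The compounds shown leave open whether in this assay the 2,3-dichlorophenyl and 3,4-dichlorophenyl groups differ at all.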